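The compounds below may be only part of what the source reports. "The series", "measured", "known", "first", "only" and "open" are said of these compounds alone.

For the measured compounds named here, in a functional assay (on this read-out lower numbers stand for stronger inhibition and higher numbers for weaker inhibition), two compounds sharing one core have numbers so far. Compound 1 `CC(C)=CCOc1ccc2c(c1)OC(c1ccccc1Cl)CC2=O` gives 8020 nM, and compound 2 `CC(C)=CCOc1ccc2c(c1)OC(c1ccc(C)cc1)CC2=O` gives 4440 nM. Compound 2 therefore stands within the scatter of compound 1, and the two cannot be ranked. Compound 3 `COc1ccc(C2CC(=O)c3ccc(OCC=C(C)C)cc3O2)cc1` alters compound 2 at a single place: methoxy in place of methyl on an aromatic carbon. In words, this is methoxy in place of methyl on an aromatic carbon, or 4-methylphenyl to 4-methoxyphenyl. Going by the values given here, only one measured step bears on it, a 1.8-fold lower number from compound 1 to compound 2 (0.26 log units; within the scatter), and that step stays within the scatter. It involves a different exchange, so it is only a loose guide. On that evidence, no step beyond the scatter is expected in this assay, in either direction. Compound 3 is estimated at 4500 nM, with an expected range of 2200 nM to 9500 nM. The expected change is a 1.0-fold higher number from compound 2 to compound 3 (0.01 log units; within the scatter).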

Compound 3, half-maximal inhibitory concentration: 10200 nM
The estimate for compound 3 lay 2.3-fold (0.36 log units) below the measured number, and the stated range ends below it.
By their numbers in this assay, from the lowest: compounds 2, 1 and 3 (each within the scatter of the next, the first and the last beyond it).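

In this assay, for the compounds shown here, the place on the aromatic ring that carries the methyl group of compound 2 turns out to respond to the exchange: methoxy in place of methyl gives a 2.3-fold higher number from compound 2 to compound 3 (0.36 log units; beyond the scatter), a modest step toward weaker inhibition and the only single exchange here that lies beyond the scatter. The 4-methoxyphenyl group of compound 3 does not separate from the 2-chlorophenyl group of compound 1, however, with a 1.3-fold higher number from compound 1 to compound 3 (0.10 log units; within the scatter), so those two compounds cannot be ranked. Nothing available explains the step from methyl to methoxy.

The compounds shown leave open how this place would read with a hydroxy group, an amine or a longer chain such as ethoxy. They also leave open whether an unsubstituted phenyl ring would stand with compound 2 or with compound 3.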